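Working notes: from compound 2 to compound 3

The source may report more compounds than this note shows. Statements on the series, on what has been measured and on what is new or still open speak of the compounds shown alone.

Values in a toxicity assay on MDCK cells (Canis lupus familiaris) for cytotoxicity, read by CCK-8 assay, with a stated time of 48 h (a lower number here means that less compound is tolerated, a higher number that more compound is tolerated), both of them limits:
Compound 1 (`CCCCOc1ccc(C(=O)NNc2c(Br)cccc2Br)cc1`) gives > 100000 nM as a limit.
Compound 2 (`O=C(NNc1c(Br)cccc1Br)c1ccccc1`) gives > 100000 nM as a limit.

Within the data shown here, compound 2 therefore has no numerical value, and the only other value is a limit too (the limit of > 100000 nM in this assay, at which 2 of the 2 values shown sit). Compound 3 (`O=C(NNc1c(Br)cccc1Br)c1ccc(B(O)O)cc1`) differs from compound 2 by a group of 3 heavy atoms (1 boron, 2 oxygen; no ring) in place of a hydrogen atom, on an aromatic carbon and carries the new group on an aromatic carbon, para to a large group. Among the measured compounds shown here, the one measured step (a step that the two limits leave unreadable from compound 1 to compound 2) has no readable size, so it offers no size to carry over. For the measured compounds named here, for compound 2 the expectation rests on the limit > 100000 nM alone, and no step of known size or direction is expected in this assay from this change. The estimate means a number no higher from compound 2 to compound 3 (the limit leaves the size open) as the expected change. Compound 3 is expected at 100000 nM (estimated range 40000 nM to 250000 nM), and may well be reported only as a limit again.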

Compound 3, half-maximal cytotoxic concentration: > 100000 nM
Compound 3 gave a limit, no number; the forecaster's own chance of this, stated with the estimate: 70%; the middle value sits exactly at the limit.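

No step can be read among compound 1, compound 2 and compound 3 in this assay, as all three values are limits: the limit of > 100000 nM in this assay, at which 3 of the 3 values shown sit.

The compounds shown leave open at what concentration any of the three becomes cytotoxic, and whether butoxy, hydrogen and the boron-bearing group differ at all in this assay.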